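A few compounds are considered here, and "the series" means these few. Any claim that something is new, unique, unknown or untested is made for them only; others in the source may bear on it.

Working notes on the series. Among the measured compounds shown here, compound 3 `CN1CCN(c2ccc(Nc3nc(-c4cccc(NC(=O)c5ccc(C(C)(C)C)cc5)c4)sc3C(N)=O)cc2)CC1` gives 80.1% in a functional assay on Ramos cells (Homo sapiens) for antiproliferative activity, read by CCK-8 assay, with a stated time of 72 h, tested at 40 uM (on this read-out lower numbers stand for less inhibition and higher numbers for more inhibition at the one concentration tested (going by the name of the read-out)), and stands lowest of the three numbers measured so far. Its nearest neighbour is compound 1 `CN1CCN(c2ccc(Nc3nc(-c4cccc(NC(=O)c5cccc(F)c5)c4)sc3C(=O)O)cc2)CC1`, which in this assay gives 82.7%, a gap within the scatter; furthest is compound 2 `CN1CCN(c2ccc(Nc3nc(-c4cccc(NC(=O)c5ccc(C(F)(F)F)cc5)c4)sc3C(N)=O)cc2)CC1`, which in this assay gives 97.8%, beyond the scatter. For the measured compounds named here, the only measured step at this position is a number 17.7 percentage points lower from compound 2 to compound 3 (beyond the scatter).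

Compound 4 `CN1CCN(c2ccc(Nc3nc(-c4cccc(NC(=O)c5cccc(F)c5)c4)sc3C(N)=O)cc2)CC1` differs from compound 3 by 3-fluorophenyl in place of 4-(tert-butyl)phenyl on a carbonyl carbon. Going by the values given here, no measured step covers this exact exchange. The step of a number 17.7 percentage points lower from compound 2 to compound 3 (beyond the scatter) bears on it only loosely, as it concerns a different pair of groups at the same carbonyl carbon and was modest. Compound 1, which carries the same 3-fluorophenyl group but differs from compound 4 elsewhere, sits within the scatter of compound 3 in this assay. The expected step of a number 4.9 percentage points higher from compound 3 to compound 4 (within the scatter) is therefore small, upward if anything, and within the scatter. Compound 4 is estimated at 85% in this assay, with a range from 70% to 98%.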

Compound 4, a percentage reported as inhibition, at one concentration (the size of the read-out at that concentration, not a potency): 16.2%
Compound 4: middle estimate off by 68.8 percentage points, on the high side; measured number below the stated range.
By their numbers in this assay, from the lowest: compound 4; then compounds 3 and 1 (each within the scatter of the next); then compound 2.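

Putting 3-fluorophenyl on the carbonyl carbon gives a number 63.9 percentage points lower from compound 3 to compound 4 (beyond the scatter) and a number 81.6 percentage points lower from compound 2 to compound 4 (beyond the scatter) in this assay, so this position can carry a large change, which the earlier modest step did not reveal. With 3-fluorophenyl held constant, amino in place of hydroxy gives a number 66.5 percentage points lower from compound 1 to compound 4 (beyond the scatter), yet amino alone does not accompany a low number, since compound 2 and compound 3 also carry it, so the read-out here depends on the pairing of the two groups. No measured evidence accounts for this result.

From the compounds shown here alone, whether the loss follows the fluorine, its place on the ring or the absence of a larger group remains open, and a 4-fluorophenyl or plain phenyl group on the same carbonyl carbon would separate these. Also open, going by these compounds, is how a carboxylic acid behaves when paired with 4-(trifluoromethyl)phenyl or 4-(tert-butyl)phenyl.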